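The source may report more compounds than this note shows. Statements on the series, on what has been measured and on what is new or still open speak of the compounds shown alone.

Compound 1 `CCCCCCCCCCCCCCNC(=O)[C@@H](NC(=O)c1ccccc1)[C@@H](C)O` gives 24800 nM in a functional assay on MCF7 cells (Homo sapiens) for cytotoxicity, read by MTT assay, with a stated time of 48 h; on this read-out lower numbers stand for stronger inhibition and higher numbers for weaker inhibition. Compound 2 `C/C=C/C=C/C(=O)N[C@H](C(=O)NCCCCCCCCCCCCCC)[C@@H](C)O` gives 27800 nM in this assay.

Compound 2 holds the highest of the two numbers, yet its difference from compound 1 is only a 1.1-fold higher number from compound 1 to compound 2 (0.05 log units; within the scatter), which is within the scatter. Compound 3 `CCCCCCCCCCCCCCNC(=O)[C@@H](NS(=O)(=O)c1cccs1)[C@@H](C)O` differs from compound 2 by (thiophen-2-yl)sulfonyl in place of (penta-1,3-dien-1-yl)carbonyl on an amine nitrogen. Within the data shown here, no measured step exchanges a carbonyl for a sulfonyl at this nitrogen, so the only guide is that swapping the group on that carbonyl, from compound 1 to compound 2, changed little. Compound 3 is therefore expected near compound 2, with a 1.0-fold higher number from compound 2 to compound 3 (0.00 log units; within the scatter), giving an estimate of 28000 nM (range 9000 nM to 90000 nM).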

Compound 3, half-maximal inhibitory concentration: 18700 nM
Compound 3: middle estimate off by 1.5-fold (0.18 log units), on the high side; the range from low to high includes it.
By their numbers in this assay, from the lowest: compounds 3, 1 and 2 (each within the scatter of the next).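

The earlier pair only swapped the group on a carbonyl, whereas compound 3 puts a sulfonyl on the amine nitrogen in place of the carbonyl, and both new steps still lie within the scatter (a 1.5-fold lower number from compound 2 to compound 3 (0.17 log units; within the scatter)) and (a 1.3-fold lower number from compound 1 to compound 3 (0.12 log units; within the scatter)). These values therefore do not separate (thiophen-2-yl)sulfonyl, benzoyl and (penta-1,3-dien-1-yl)carbonyl at this nitrogen. No measurement shown here offers an explanation for this result.

Going by these compounds, whether a free amine or a small acetyl group on this nitrogen would move the number beyond the scatter remains open. The long chain is the same in all the compounds shown, so the effect of a shorter chain is also unknown.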